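The source may hold more compounds than are shown below. What is called first, only, known or untested is meant among the compounds shown, and "the series" means these compounds.

Measured in a functional assay on MCF7 cells (Homo sapiens) for inhibition, read by MTT assay, with a stated time of 48 h, tested at 10 uM; on this read-out lower numbers stand for less inhibition of growth and higher numbers for more inhibition of growth at the one concentration tested:
- compound 1 `Cc1cc(=O)c2c(O)cc(OC/C=C/c3ccccc3)c([C@H]3CCN(C)C[C@H]3O)c2o1`: 7%
- compound 2 `Cc1cc(=O)c2c(O)c(CN3CCCC3CO)c(O)c([C@H]3CCN(C)C[C@H]3O)c2o1`: 22%
- compound 3 `CN1CC[C@H](c2c(O)cc(O)c3c(=O)cc(/C=C/c4ccc(Cl)cc4)oc23)[C@H](O)C1`: 10%

Not yet measured: compound 4 `CN1CC[C@H](c2c(O)cc(O)c3c(=O)cc(/C=C/c4c(F)c(F)c(F)c(F)c4F)oc23)[C@H](O)C1`.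

Compound 3 is second highest of the three numbers. At 10%, compound 3 lies within the scatter of compound 1. The gap from compound 3 to compound 2 goes beyond the scatter, with compound 2 the higher at 22%.

The next compound keeps the shared core of compound 3 and changes one group. Compound 4 has 2,3,4,5,6-pentafluorophenyl in place of 4-chlorophenyl on a double-bonded chain carbon bound to a double-bonded chain carbon.

Going by the values given here, no two measured compounds differ in one place only, so the series offers no direct measure of what such a swap does. The expectation therefore starts from compound 3 at 10%. With no evidence for a direction, no step beyond the scatter is expected in this assay, though a modest rise or fall remains possible. The estimated change is small, a number 2 percentage points higher from compound 3 to compound 4 (within the scatter), and lies within the scatter. For compound 4 the expected value is 12%, with an estimated range of 3% to 27%.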

Compound 4, percent growth inhibition at one concentration: 64%
Estimate against measurement, compound 4: 52 percentage points below; measured number outside the range, above it.
By their numbers in this assay, from the lowest: compounds 1 and 3 (each within the scatter of the next); then compound 2; then compound 4.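

In this assay, 2,3,4,5,6-pentafluorophenyl in place of 4-chlorophenyl on a double-bonded chain carbon bound to a double-bonded chain carbon gives a number 54 percentage points higher from compound 3 to compound 4 (beyond the scatter), the first single-place step the series can read. This position is therefore not indifferent to what the aromatic ring carries: the six-membered aromatic ring of carbon stays, neither group has hydrogen-bond donors, hydrogen-bond acceptors or a net charge, and the exchange of chlorine for fluorine comes with a large shift in growth inhibition at the one concentration tested. Nothing at hand shows which feature of the swap accounts for the step.

The compounds shown leave open whether the full set of fluorines is needed, or whether a single fluorine, a trifluoromethyl group, a nitrile or a pyridine ring at this place would give a similar result. They also leave open whether the same swap would have a comparable effect on the cores of compound 1 and compound 2, and how compound 4 would behave at other concentrations in this assay.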